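Shifting a Hydroxy Group on the Shared Core

The compounds below may be only part of what the source reports. "The series", "measured", "known", "first", "only" and "open" are said of these compounds alone.

Compound 1 `Oc1ccc(/C=N/NC(=S)Nc2ccccc2)cc1` is the weaker of the two measured compounds in an assay for inhibition of ribonucleoside-diphosphate reductase RR1 (Homo sapiens), with a stated time of 30 min (a lower number here means a stronger inhibitor, a higher number a weaker inhibitor), where compound 1 gives 242000 nM, the highest of the two numbers. Compound 2 `Oc1ccc(/C=N/NC(=S)Nc2ccccc2O)cc1` differs from it by a single added hydroxy on the same ring and gives 29300 nM; this step was an 8.3-fold lower number from compound 1 to compound 2 (0.92 log units; beyond the scatter). Compound 3 `Oc1ccc(/C=N/NC(=S)Nc2cccc(O)c2)cc1` carries its added hydroxy at a different carbon of that ring: hydroxy in place of hydrogen on an aromatic carbon. Among the compounds with values here, the only measured step that bears on this change is the one from compound 1 to compound 2, which was modest but clearly beyond the scatter. Within the data shown here, the new placement has no direct precedent here, so a shift in the same direction but of smaller size is expected, a 3.5-fold lower number from compound 1 to compound 3 (0.54 log units; beyond the scatter). Compound 3 is therefore estimated at 70000 nM, with a range from 20000 nM to 250000 nM.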

Compound 3, half-maximal inhibitory concentration: 28600 nM
For compound 3 the middle estimate is 2.4-fold (0.39 log units) above the measured one; the range from low to high includes it.
By their numbers in this assay, from the lowest: compounds 3 and 2 (each within the scatter of the next); then compound 1.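

In this assay, within the data shown here, hydroxy in place of hydrogen on the aromatic carbon meta to a large group gives an 8.5-fold lower number from compound 1 to compound 3 (0.93 log units; beyond the scatter), so the lower number seen earlier is not tied to the single placement in compound 2. Compound 2 gives 29300 nM and compound 3 gives 28600 nM, two values within the scatter of each other, so this assay does not separate these two placements. No measurement is available to explain why the two placements read alike.

Still open, on these data alone, is whether the carbon carrying the new hydroxy would accept a different group, such as methoxy, an amine or a carboxylic acid. Also open, as far as these compounds go, is whether a second added hydroxy on the same ring would lower the number further.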